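The source may report more compounds than this note shows. Statements on the series, on what has been measured and on what is new or still open speak of the compounds shown alone.

Compound 2 `CCc1c(F)c(N)c2c(=O)cc(-c3ccc(N)c(F)c3)oc2c1F` gives 130 nM in a functional assay on MCF7 cells (Homo sapiens) for cytotoxicity, read by neutral red uptake, with a stated time of 3 days (on this read-out lower numbers stand for stronger inhibition and higher numbers for weaker inhibition), which places it second highest of the three numbers at hand. Compound 1 `Nc1ccc(-c2cc(=O)c3c(N)c(F)cc(F)c3o2)cc1F` gives 40 nM in this assay, and compound 3 `[N-]=[N+]=Nc1c(F)c(N)c2c(=O)cc(-c3ccc(N)c(F)c3)oc2c1F` gives 460 nM in this assay. Compound 4 `CCCCCC(=O)NCc1c(F)c(N)c2c(=O)cc(-c3ccc(N)c(F)c3)oc2c1F` has not yet been measured; it differs from compound 2 by (pentylcarbonyl)amino in place of methyl on a saturated chain carbon bound to an aromatic carbon. Among the compounds with values here, three measured steps bear on this change. Ethyl in place of hydrogen on an aromatic carbon gave a 3.3-fold higher number from compound 1 to compound 2 (0.51 log units; beyond the scatter); azido in place of hydrogen on that aromatic carbon gave a 12-fold higher number from compound 1 to compound 3 (1.06 log units; beyond the scatter); azido in place of ethyl there gave a 3.5-fold higher number from compound 2 to compound 3 (0.55 log units; beyond the scatter). Every enlargement at this part of the shared core has so far raised the number in this assay, and the change to compound 4 enters a group far larger than any seen among the measured compounds, though none of them carries a group of this kind. Compound 4 is therefore expected to show a higher number in this assay, with a step of a 4.6-fold higher number from compound 2 to compound 4 (0.66 log units; beyond the scatter). The estimate for compound 4 in this assay is 600 nM, with a range from 200 nM to 2000 nM.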

Compound 4, half-maximal inhibitory concentration: 340 nM
Compound 4: the middle estimate sits 1.8-fold (0.25 log units) above what was measured, and the stated range covers the measured number.
By their numbers in this assay, from the lowest: compound 1; then compound 2; then compounds 4 and 3 (each within the scatter of the next).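

Placing (pentylcarbonyl)amino in place of methyl on a saturated chain carbon bound to an aromatic carbon raised the number only modestly in this assay (a 2.6-fold higher number from compound 2 to compound 4 (0.42 log units; beyond the scatter)), so this position accepts a far larger group than any carried by the earlier compounds while the number stays in the range they span. Size alone does not set the number here, as the much larger ((pentylcarbonyl)amino)methyl group and azido could not be told apart (a 1.4-fold lower number from compound 3 to compound 4 (0.13 log units; within the scatter)), although hydrogen still gives the lowest number of the four compounds (an 8.5-fold higher number from compound 1 to compound 4 (0.93 log units; beyond the scatter)). No measurement shown here accounts for this result.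

As far as these compounds go, it remains open how much of the step belongs to the pentyl chain and how much to the amide link. An aminomethyl group, a shorter acetylamino chain or a longer chain ending in a carboxylic acid at this position would begin to separate the two.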